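Solubility notes on a sulfonamide series

The compounds below may be only part of what the source reports. "The series", "measured", "known", "first", "only" and "open" are said of these compounds alone.

Measured so far in a physicochemical assay for solubility, read by HPLC, using the shake flask method, measured as kinetic solubility, with a stated time of 20 h, at pH 6.5, tested at 200 uM; on this read-out lower numbers stand for lower solubility and higher numbers for higher solubility:
- compound 1, `O=S(=O)(c1cccc(Nc2ccc3nccc(-c4ccncc4)c3n2)c1)N1CCCC1`: < 5000 nM
- compound 2, `O=S(=O)(NCCO)c1cccc(-c2ccc3nccc(-c4ccc(OC(F)(F)F)cc4)c3n2)c1`: < 5000 nM
- compound 3, `O=S(=O)(NCC1COC1)c1cccc(-c2ccc3nccc(-c4ccncc4)c3n2)c1`: 20000 nM.

Compound 1 is known in this assay only through a limit, < 5000 nM, not a number. For compound 2 the read-out is likewise a limit, < 5000 nM. Compound 3 stands apart in that it gives a measured number, 20000 nM. Compound 1 therefore sits at the lower edge of what is shown, and the shared limit of < 5000 nM in this assay, at which 2 of the 3 values shown sit, marks where two of the three compounds rest; no step between any pair of measured compounds has been worked out, so the three values are taken only as they stand.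

The unmeasured compound 4, `NCCNS(=O)(=O)c1cccc(Nc2ccc3nccc(-c4ccncc4)c3n2)c1`, is compound 1 with one change: (2-aminoethyl)amino in place of pyrrolidin-1-yl on a sulfonyl sulfur. The change removes the five-membered ring and brings in a chain with two hydrogen-bond donors and one acceptor on the sulfonyl sulfur.

For the measured compounds named here, no measured step covers this kind of change. Because compound 1 is known only through the limit < 5000 nM, the size of the move in this assay can only be guessed. The expectation is an increase well beyond the usual scatter, with the step of an at least 12-fold higher number from compound 1 to compound 4 (1.07 log units; beyond the scatter) expected to carry compound 4 past where compound 3 stands with 20000 nM. The estimate for compound 4 in this assay is 60000 nM, with a range from 10000 nM to 200000 nM expected.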

Compound 4, solubility: 200000 nM
Compound 4: middle estimate off by 3.3-fold (0.52 log units), on the low side; measured number inside the range.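

The series now has its first step in this assay, and it is large, with an at least 40-fold higher number from compound 1 to compound 4 (1.60 log units; beyond the scatter) on going from pyrrolidin-1-yl to (2-aminoethyl)amino on a sulfonyl sulfur. Compound 4 gives 200000 nM as a plain number, the same figure as the concentration tested, so the read-out leaves no visible room beyond compound 4. Compound 1 remains a limit and not a number, so the step is a floor and its true size stays unknown: the limit of < 5000 nM in this assay, at which 2 of the 4 values shown sit.

Open, going by these compounds, is which part of the change goes with the step: the terminal amine, the loss of the five-membered ring or the open chain, which piperazin-1-yl or (3-aminopropyl)amino on the same sulfonyl sulfur, or a chain ending in a carboxylic acid, would help to separate. Also open, on these data alone, is whether the change gives a step of similar size on another core, since it rests so far on this single pair of compounds.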